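This account rests on a few compounds, and the source may have more. Where it says the series, first, only, none or still open, it means among the compounds named here.

Measured so far in a functional assay on K562 cells (Homo sapiens) for antiproliferative activity, read by MTT assay, with a stated time of 24 h; a lower number here means a stronger inhibitor, a higher number a weaker inhibitor:

compound 1 `COc1cccc(/C=C/C(=O)c2ccc(OC)c3c2OC(C)(C)C=C3)c1` gives > 10000 nM, which is a limit of the assay and not a number.
compound 2 `COc1ccc(C(=O)/C=C/c2ccc(-c3ccccc3)cc2)c2c1C=CC(C)(C)O2` gives > 10000 nM, likewise a limit of the assay.
compound 3 `COc1ccc(/C=C/C(=O)c2ccc(OC)c3c2OC(C)(C)C=C3)cn1` gives > 10000 nM, again a limit of the assay.

Compound 3 thus stands only at a limit in this assay, and the two further values shown for the series are limits as well. For the measured compounds named here, the one single-point step among the measured compounds, a step that the two limits leave unreadable from compound 1 to compound 3, cannot be read in size or direction, since both ends sit at the limit.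

Compound 4 `COc1ccc(C(=O)/C=C/c2ccc(O)c(Br)c2)c2c1C=CC(C)(C)O2` is the next member. Its difference from compound 3 is 3-bromo-4-hydroxyphenyl in place of 6-methoxypyridin-3-yl on a double-bonded chain carbon bound to a double-bonded chain carbon.

Going by the values given here, no measured step bears directly on this change: the exchange of the aromatic group on the chain has so far been tested only in the unreadable step from compound 1 to compound 3. What the series does show is the limit of > 10000 nM in this assay, at which 3 of the 3 values shown sit, and because the limit of > 10000 nM in this assay, at which 3 of the 3 values shown sit, holds for every member measured, the working expectation is that compound 4 will most likely also end at the limit rather than at a readable number. The step that the limit leaves unreadable from compound 3 to compound 4 is therefore expected to be small or not readable at all. On this basis compound 4 is estimated at 15000 nM, with a range from 3000 nM to 60000 nM.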

Compound 4, half-maximal inhibitory concentration: > 10000 nM
Compound 4: no number, only a limit (the forecaster's own chance of this, stated with the estimate: 70%); the middle value is on the limit's open side.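

In this assay compound 4 gives > 10000 nM as a limit of the assay and not a number. The steps to compound 4 from compound 1 and from compound 3 cannot be read: the limit of > 10000 nM in this assay, at which 4 of the 4 values shown sit. The compounds shown leave open whether any group on the chain carbon reaches a readable value in this assay and how these groups rank.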